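This account rests on a few compounds, and the source may have more. Where it says the series, first, only, none or still open, it means among the compounds named here.

Compound 1 `COc1ccc(-c2noc(CCCCCCC(=O)NO)n2)cc1` and compound 2 `Cc1ccc(-c2noc(CCCCCCC(=O)C(F)(F)F)n2)cc1` share a core carrying a seven-carbon chain. In an assay on isolated protein for inhibition of histone deacetylase 8 (Homo sapiens), read by fluorescence, with a stated time of 10 min (on this read-out higher numbers stand for weaker inhibition and lower numbers for stronger inhibition), compound 1 reaches only a limit, > 10000 nM, not a number. For the measured compounds named here, compound 2 gives 3190 nM in this assay, the single number so far, as the other entry is the limit of > 10000 nM in this assay, at which 1 of the 2 values shown sits. Compound 3 `COc1ccc(-c2noc(CCCCCCC(=O)C(F)(F)F)n2)cc1` differs from compound 2 by methoxy in place of methyl on an aromatic carbon. Going by the values given here, no measured step informs this change, so the step of a 1.3-fold higher number from compound 2 to compound 3 (0.10 log units; within the scatter) is expected to be small, at most modestly weaker. Compound 3 is estimated at 4000 nM, ranging from 1500 nM to 12000 nM.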

Compound 3, half-maximal inhibitory concentration: 1860 nM
Compound 3: the middle estimate sits 2.2-fold (0.33 log units) above what was measured; measured number inside the range.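

The change from 4-methylphenyl to 4-methoxyphenyl gives a 1.7-fold lower number from compound 2 to compound 3 (0.23 log units; within the scatter) in this assay, so methyl and methoxy cannot be told apart at this place, para to a large group. For the compounds shown here, with the methoxy held constant, trifluoromethyl in place of hydroxyamino on the carbonyl carbon gives an at least 5.3-fold lower number from compound 1 to compound 3 (0.73 log units; beyond the scatter), the first step that can be read beyond the scatter. Compound 1 stands only at a limit, not at a number: the limit of > 10000 nM in this assay, at which 1 of the 3 values shown sits.

On these data alone, how an amine or a chlorine atom at the same aromatic carbon would read stays open. So does the effect of a carboxylic acid in place of the trifluoromethyl, or of a longer chain.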